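Sulfonamide series: aryl swap on the sulfonyl sulfur

The compounds below may be only part of what the source reports. "The series", "measured", "known", "first", "only" and "open" are said of these compounds alone.

Measured compounds:
compound 1 `COc1ccccc1-c1cccc(S(=O)(=O)N2CCC(N3CCC(C)CC3)CC2)c1` — in a functional assay on DLD-1 cells (Homo sapiens) for antiproliferative activity, read by CellTiter-Glo, with a stated time of 72 h (a higher number here means a weaker inhibitor, a lower number a stronger inhibitor), compound 1 gives 21 nM
compound 2 `Cc1nc(Cl)sc1S(=O)(=O)N1CCC(N2CCC(C)CC2)CC1` — in this assay compound 2 gives 1.6 nM

Compound 2 holds the lowest of the two numbers in this assay; compound 1 sits higher, and that gap lies beyond the usual scatter. Among the measured compounds shown here, no pair among the measured compounds differs in only one place, so no single-change step is available from the data as they stand.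

Compound 3 `Cc1cccc(S(=O)(=O)N2CCC(N3CCC(C)CC3)CC2)c1` is the next to be measured. It differs from compound 2 in one place: 3-methylphenyl in place of 2-chloro-4-methyl-1,3-thiazol-5-yl on a sulfonyl sulfur. Across the two measured compounds, the group on the sulfonyl sulfur is the only part that varies, and the six-membered carbon ring of compound 1 goes with the higher number. On that basis the step of a 9.4-fold higher number from compound 2 to compound 3 (0.97 log units; beyond the scatter) is expected to run upward, toward a weaker inhibitor, by more than the scatter. Compound 3 is expected to give about 15 nM, within a range from 4 nM to 60 nM. The range is kept wide: only compound 1, with 21 nM, anchors a six-membered carbon ring in this series.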

Compound 3, half-maximal inhibitory concentration: 25 nM
Estimate against measurement, compound 3: 1.7-fold (0.22 log units) below; measured number inside the range.
By their numbers in this assay, from the lowest: compound 2; then compounds 1 and 3 (each within the scatter of the next).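

In this assay the group on the sulfonyl sulfur can now be read as a single change: a 16-fold higher number from compound 2 to compound 3 (1.19 log units; beyond the scatter), with 3-methylphenyl in place of 2-chloro-4-methyl-1,3-thiazol-5-yl at the same count of heavy atoms, so the number at this position responds to the kind of ring and not only to the size of the group. The second step shows a different picture on the carbon ring: a 1.2-fold higher number from compound 1 to compound 3 (0.08 log units; within the scatter), with methyl in place of 2-methoxyphenyl on an aromatic carbon, so this much larger exchange does not separate the two compounds. Nothing available explains either step.

The compounds shown leave open which part of 2-chloro-4-methyl-1,3-thiazol-5-yl carries the large step, as its chlorine, its methyl and its ring hetero atoms all leave together in this one change. Going by these compounds, whether a pyridine ring on the sulfonyl sulfur would stay with compound 2 or with compound 3, and whether an amine or a carboxylic acid in place of the methyl of compound 3 would shift the number, also remains open.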